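The compounds below may be only part of what the source reports. "The series", "measured", "known", "first", "only" and "open" are said of these compounds alone.

Compounds measured in an assay on membranes from lung (Cavia porcellus) for binding affinity to cysteinyl leukotriene receptor (Homo sapiens); on this read-out lower numbers stand for stronger inhibition and higher numbers for weaker inhibition:
compound 1 `CC(CCC(=O)O)Cc1cccc(OCc2ccc3ccccc3n2)c1`, 140 nM
compound 2 `O=C(O)CCC(Cc1cccc(OCc2ccc3ccccc3n2)c1)c1ccccc1`, 52 nM

Going by the values given here, compound 2 gives the lowest of the two numbers in this assay; the nearest is compound 1, and the only measured step, a 2.7-fold lower number from compound 1 to compound 2 (0.43 log units; beyond the scatter), separates the two.

Compound 3 `c1ccc(C(CCc2nnn[nH]2)Cc2cccc(OCc3ccc4ccccc4n3)c2)cc1` is not yet measured in this assay. It differs from compound 2 in one place: 1H-tetrazol-5-yl in place of carboxy on a saturated chain carbon, three bonds along the chain from an aromatic carbon. Among the compounds with values here, no measured step bears on this change; the single step in hand, a 2.7-fold lower number from compound 1 to compound 2 (0.43 log units; beyond the scatter), concerns phenyl in place of methyl on the chain and says nothing about the acid end. The expectation for compound 3 therefore rests on compound 2 alone, at 52 nM, and carries a wide range. Compound 3 is expected to give about 40 nM, between 10 nM and 200 nM. The expected step, a 1.3-fold lower number from compound 2 to compound 3 (0.11 log units; within the scatter), is none beyond the scatter.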

Compound 3, inhibition constant: 14 nM
Compound 3: middle estimate off by 2.9-fold (0.46 log units), on the high side; low and high end bracket the measured number.
By their numbers in this assay, from the lowest: compound 3; then compound 2; then compound 1.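

Until now only the chain substituent had been varied, and the acid end of the molecule had not been tested. In this assay, replacing carboxy with 1H-tetrazol-5-yl on the phenyl-bearing chain gives a 3.7-fold lower number from compound 2 to compound 3 (0.57 log units; beyond the scatter), so this end of the chain also affects the read-out and carboxy is not needed to hold the number of compound 2. Nothing available explains why the exchange gives this step.

Going by these compounds alone, this exchange is seen only with phenyl on the chain, so it remains open whether it would give a similar step with the methyl of compound 1. Also open, on these data alone, is how an acylsulfonamide at this position, or a longer chain carrying 1H-tetrazol-5-yl, would compare with compound 3.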